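One Methyl Added to the Butoxy Chain of Compound 1

The compounds below may be only part of what the source reports. "The series", "measured", "known", "first", "only" and "open" are said of these compounds alone.

Compound 1 `CCCCOc1ccc(C(=O)/C=C/c2c(/C=C/c3ccc(OC)cc3)cc(OC)cc2OC)cc1` is one of three measured compounds. In a functional assay on HepG2 cells (Homo sapiens) for antiproliferative activity, read by MTT assay, with a stated time of 48 h (a lower number here means a stronger inhibitor, a higher number a weaker inhibitor), compound 1 gives 12.9 ug/mL, the second highest of the three numbers. Its nearest neighbour is compound 3 `COc1ccc(/C=C/c2cc(OC)cc(OC)c2/C=C/C(=O)c2ccc(Cl)c(Cl)c2)cc1`, which in this assay gives 10.8 ug/mL; the furthest is compound 2 `CCCCCCOc1ccc(C(=O)/C=C/c2c(/C=C/c3ccc(OC)cc3)cc(OC)cc2OC)cc1`, which gives 16.2 ug/mL. Both lie within the scatter of compound 1: a 1.2-fold lower number from compound 1 to compound 3 (0.08 log units; within the scatter) and a 1.3-fold higher number from compound 1 to compound 2 (0.10 log units; within the scatter).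

Compound 4 `CCCC(C)Oc1ccc(C(=O)/C=C/c2c(/C=C/c3ccc(OC)cc3)cc(OC)cc2OC)cc1` differs from compound 1 by methyl in place of hydrogen on a saturated chain carbon bound to an oxygen on an aromatic ring and a saturated chain carbon. Going by the values given here, the only measured step that touches the same region is the one extending the same chain further out, a 1.3-fold higher number from compound 1 to compound 2 (0.10 log units; within the scatter), which stayed within the scatter. Among the compounds with values here, the change to compound 4 is of a related kind, a methyl on the same butoxy chain, and no measured step points in any direction beyond the scatter. One therefore expects a 1.0-fold higher number from compound 1 to compound 4 (0.00 log units; within the scatter) for compound 4. The estimate for compound 4 is 13 ug/mL, with a range from 7 ug/mL to 25 ug/mL.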

Compound 4, half-maximal inhibitory concentration: 11.1 ug/mL
Beside the measured number, compound 4's estimate is 1.2-fold (0.07 log units) above it; the measured number falls inside the stated range.
By their numbers in this assay, from the lowest: compounds 3, 4, 1 and 2 (each within the scatter of the next).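

Methyl in place of hydrogen on the saturated chain carbon bound to the oxygen on the aromatic ring gives a 1.2-fold lower number from compound 1 to compound 4 (0.07 log units; within the scatter) in this assay, which shows that this carbon of the butoxy chain, and not only the far end of the chain, can carry the change without a shift beyond the scatter. The 1-methylbutyl group in place of hexyl gives a 1.5-fold lower number from compound 2 to compound 4 (0.16 log units; within the scatter) as well. Even 4-(1-methylbutoxy)phenyl in place of 3,4-dichlorophenyl gives only a 1.0-fold higher number from compound 3 to compound 4 (0.01 log units; within the scatter), and no step among these four compounds yet separates them in this assay.

No available evidence bears on why this position accepts the methyl. Going by these compounds, whether an ethyl, a hydroxyl or an amine on the same carbon would move the number beyond the scatter remains open.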